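Acid Dissociation Expected for a Hybrid Benzylamine, Compound 3

The source may hold more compounds than are shown below. What is called first, only, known or untested is meant among the compounds shown, and "the series" means these compounds.

Measured compounds:
compound 1, `COc1cccc(CNCCCNc2ccnc3cc(CCC(C)C)ccc23)c1O` — 9.47
compound 2, `COc1ccc(F)cc1CNCCCNc1ccnc2cc(-c3cccc4ccccc34)ccc12` — 9.47

In a physicochemical assay for acid dissociation, compound 1 gives 9.47. Compound 2, which carries a different aryl group on the benzylic carbon and a different substituent on the shared core, gives 9.47 in this assay. Compound 2 thus stands level with compound 1 at the digits shown; the two values lie within the usual scatter of each other, and no difference between them can be claimed.

Compound 3, `COc1cccc(CNCCCNc2ccnc3cc(-c4cccc5ccccc45)ccc23)c1O`, has not yet been measured. It differs from compound 2 in one place: 2-hydroxy-3-methoxyphenyl in place of 5-fluoro-2-methoxyphenyl on a saturated chain carbon bound to an amine nitrogen. Compound 3 therefore joins the benzylic aryl group of compound 1 to the core of compound 2.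

For the measured compounds named here, no step between two measured compounds differing in a single place is available. The step from compound 2 to compound 3 is expected to be no change at the digits printed from compound 2 to compound 3 (within the scatter), that is, no change beyond the scatter, because compound 1, which already carries the entering group, gives 9.47. Compound 3 is thus estimated at 9.47, with a range from 9.15 to 9.8.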

Compound 3, acid dissociation constant: 9.47
For compound 3 middle estimate and measured number coincide at the digits printed; low and high end bracket the measured number.
By their numbers in this assay, from the lowest: compounds 1, 2 and 3 (each within the scatter of the next).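

In this assay, the exchange of 5-fluoro-2-methoxyphenyl for 2-hydroxy-3-methoxyphenyl on a saturated chain carbon bound to an amine nitrogen, read on its own with the rest of the structure held constant, gives no change at the digits printed from compound 2 to compound 3 (within the scatter); compounds 1 and 2 differ in two places, so their level values could not show this for either place alone. Compound 3 also supplies the single change on an aromatic carbon, where naphthalen-1-yl in place of isopentyl gives no change at the digits printed from compound 1 to compound 3 (within the scatter), so among these three compounds neither place shifts the reading beyond the scatter. Nothing at hand explains this result or identifies which part of the structure gives up the proton.

The compounds shown leave open whether a carboxylic acid or a dimethylamino group in place of the 2-hydroxy-3-methoxyphenyl on that chain carbon would also stay within the scatter. They also leave open whether an amine or a longer chain in place of naphthalen-1-yl on the aromatic carbon would do the same.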